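A few compounds are considered here, and "the series" means these few. Any claim that something is new, unique, unknown or untested is made for them only; others in the source may bear on it.

Among the compounds with values here, in a functional assay on MCF7 cells (Homo sapiens) for inhibition, with a stated time of 96 h (a lower number here means a stronger inhibitor, a higher number a weaker inhibitor), compound 3 (`COc1cc(C(=O)c2cn(-c3ccc(C)cc3)cc2-c2ccsc2)cc(OC)c1OC`) gives 4 nM, the lowest of the three numbers measured so far. Compound 1 (`COc1cc(C(=O)c2cn(-c3cccc(N)c3)cc2-c2ccc(N)cc2)cc(OC)c1OC`) gives 14 nM, and compound 2 (`COc1cc(C(=O)c2cn(-c3cccc(C)c3)cc2-c2ccsc2)cc(OC)c1OC`) gives 65 nM.

Compound 4 (`COc1cc(C(=O)c2cn(-c3ccc(C)cc3)cc2-c2ncco2)cc(OC)c1OC`) differs from compound 3 in one place, where 1,3-oxazol-2-yl stands in place of thiophen-3-yl on an aromatic carbon: 1,3-oxazol-2-yl in place of thiophen-3-yl on an aromatic carbon.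

Within the data shown here, only one measured step links two compounds that differ in a single place: a 16-fold lower number from compound 2 to compound 3 (1.21 log units; beyond the scatter). That large step comes from 4-methylphenyl in place of 3-methylphenyl on an aromatic nitrogen, so it lies elsewhere in the molecule and says nothing direct about the new change. Compound 1 carries another group at the changing place, but it also differs from compound 3 on the aromatic nitrogen, so it cannot isolate this swap. Among the measured compounds shown here, the step from compound 2 shows only that one small change can move the number far in this set.

For the measured compounds named here, with compound 3 at 4 nM, the lowest number so far, a moderate move to a higher number in this assay is the more likely outcome, though this is uncertain. The expected step is a 6.3-fold higher number from compound 3 to compound 4 (0.80 log units; beyond the scatter). For compound 4, the estimated value is 25 nM, with an expected range from 5 nM to 120 nM.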

Compound 4, half-maximal inhibitory concentration: 42 nM
For compound 4 the middle estimate is 1.7-fold (0.23 log units) below the measured one; measured number inside the range.
By their numbers in this assay, from the lowest: compound 3; then compound 1; then compounds 4 and 2 (each within the scatter of the next).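

In this assay, the aromatic carbon that carries thiophen-3-yl proves to be a sensitive place: an 11-fold higher number from compound 3 to compound 4 (1.02 log units; beyond the scatter), a large step of the same kind as a 16-fold lower number from compound 2 to compound 3 (1.21 log units; beyond the scatter), which arose at the aromatic nitrogen. The new step is notable for how much the two groups share, since both are five-membered aromatic rings with the same heavy-atom count and no hydrogen-bond donor, while 1,3-oxazol-2-yl has one more hetero atom and one more hydrogen-bond acceptor, with nitrogen and oxygen in the ring in place of sulfur. Keeping the ring size and the heavy-atom count therefore did not keep the number low, and no measurement here accounts for the rise.

The compounds shown leave open which difference between the two rings matters, and a 1,3-thiazol-2-yl group, with sulfur and nitrogen in the ring, or a plain phenyl at the same place would help to separate these differences. They also leave open whether this swap would give a step of similar size with 3-methylphenyl on the aromatic nitrogen in place of 4-methylphenyl.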